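Replacing cyclohexyl by methoxyphenoxy on a quinoline-type core

The compounds below may be only part of what the source reports. "The series", "measured", "known", "first", "only" and "open" are said of these compounds alone.

Measured compounds:
Compound 1 `COc1cccc(CNCCCNc2ccnc3cc(C4CCCCC4)ccc23)c1O` gives 23 10^-6 cm/s in an ADME assay for permeability, using PAMPA, with a stated time of 30 min, at pH 7.4; a lower number here means that the compound crosses the layer more slowly, a higher number that the compound crosses the layer faster.
Compound 2 `COc1ccc(F)cc1CNCCCNc1ccnc2cc(C3CCCCC3)ccc12` gives 23 10^-6 cm/s in this assay.
Compound 3 `Cc1cc(C)cc(Cc2ccc3c(NCCCNCc4ccco4)ccnc3c2)c1` gives 23 10^-6 cm/s in this assay.

Compound 1 stands level with compound 2 and compound 3 at the digits shown. For the measured compounds named here, the one step among them, no change at the digits printed from compound 1 to compound 2 (within the scatter), altered the benzylic aryl group and left the result unchanged within the scatter. Compound 4 `COc1cccc(Oc2ccc3c(NCCCNCc4cccc(OC)c4O)ccnc3c2)c1` differs from compound 1 elsewhere: 3-methoxyphenoxy in place of cyclohexyl on an aromatic carbon. Going by the values given here, no measured step touches this position, so the expectation rests on compound 1 alone. Compound 4 is therefore expected to stay close, with a step of a 1.3-fold lower number from compound 1 to compound 4 (0.11 log units; within the scatter) estimated, and a value of 18 10^-6 cm/s expected, in the range 8 10^-6 cm/s to 35 10^-6 cm/s.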

Compound 4, apparent permeability: 317 10^-6 cm/s
Beside the measured number, compound 4's estimate is 18-fold (1.25 log units) below it; the whole stated range lies below it.
By their numbers in this assay, from the lowest: compounds 1, 2 and 3 (each within the scatter of the next); then compound 4.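

In this assay, for the compounds shown here, the read-out responds strongly at the aromatic carbon carrying cyclohexyl: 3-methoxyphenoxy there gives a 14-fold higher number from compound 1 to compound 4 (1.14 log units; beyond the scatter) and so this position, unlike the benzylic aryl group with no change at the digits printed from compound 1 to compound 2 (within the scatter) as its one step, moves the number beyond the scatter. Nothing given here accounts for the size of this step.

Which part of 3-methoxyphenoxy carries the step stays open, as the compounds shown do not separate its ether oxygen, methoxy group and aromatic ring; plain phenoxy, phenyl or cyclohexyloxy on this carbon would do so. As far as these compounds go, whether the step holds with the 5-fluoro-2-methoxyphenyl group of compound 2 is also open.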